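This account rests on a few compounds, and the source may have more. Where it says the series, first, only, none or still open, it means among the compounds named here.

In an ADME assay on MT4 cells (Homo sapiens) for cytotoxicity, read by MTT assay (a lower number here means that less compound is tolerated, a higher number that more compound is tolerated), compound 1 `O=C1c2ccccc2C(=O)N1CCOC(=S)N(C(=O)c1ccc([N+](=O)[O-])cc1)c1ccc(Cl)cc1` gives > 100000 nM, which is a limit of the assay and not a number. Among the compounds with values here, compound 2 `O=C1c2ccccc2C(=O)N1CCOC(=S)N(C(=O)c1ccc([N+](=O)[O-])cc1Cl)c1ccc(Cl)cc1` gives 19000 nM, the only true number so far. Compound 3 `Cc1cc(C(=O)N(C(=S)OCCN2C(=O)c3ccccc3C2=O)c2ccc(Cl)cc2)ccc1Br` carries 4-bromo-3-methylphenyl in place of 2-chloro-4-nitrophenyl on a carbonyl carbon, (4-bromo-3-methylphenyl in place of 2-chloro-4-nitrophenyl on a carbonyl carbon). Within the data shown here, the single measured step on this group, an at least 5.2-fold lower number from compound 1 to compound 2 (0.72 log units; beyond the scatter), lies beyond the scatter, and its added chloro leaves in this change, so a modest rise in this assay is expected. The estimated change is a 2.1-fold higher number from compound 2 to compound 3 (0.32 log units; beyond the scatter). For compound 3 the expected value is 40000 nM, with an estimated range of 13000 nM to 100000 nM.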

Compound 3, half-maximal cytotoxic concentration: 18000 nM
The estimate for compound 3 lay 2.2-fold (0.35 log units) above the measured number; measured number inside the range.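

In this assay, replacing 2-chloro-4-nitrophenyl with 4-bromo-3-methylphenyl on the carbonyl carbon gives a 1.1-fold lower number from compound 2 to compound 3 (0.02 log units; within the scatter), so these two quite different groups cannot be told apart here. Compound 3 has no chloro, yet the change from 4-nitrophenyl gives an at least 5.5-fold lower number from compound 1 to compound 3 (0.74 log units; beyond the scatter), so a chloro is not required for a number this low. That step rests on a limit of the assay, not a number: the limit of > 100000 nM in this assay, at which 1 of the 3 values shown sits.

Whether the bromo or the methyl alone accounts for compound 3 stays open. So does the effect of an amine, a carboxylic acid or a longer chain at this position.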